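Propyl to isopropyl on an antiproliferative compound

A few compounds are considered here, and "the series" means these few. Any claim that something is new, unique, unknown or untested is made for them only; others in the source may bear on it.

Compound 1 `CC(C)/C=C/C(=O)Nc1cccc(Oc2nc(Nc3ccn(C)n3)nc3c2CSCC3)c1`: 33500 nM
Compound 2 `CCC/C=C/C(=O)Nc1cccc(Oc2nc(Nc3cccc(OC)c3)nc3c2CSCC3)c1`: 11800 nM
Compound 3 `COc1cccc(Nc2nc3c(c(Oc4cccc(NC(=O)/C=C/C(C)C)c4)n2)CSCC3)c1`: not yet measured

In a functional assay on A549 cells (Homo sapiens) for antiproliferative activity, read by MTT assay, with a stated time of 72 h (a lower number here means a stronger inhibitor, a higher number a weaker inhibitor), compound 2 gives 11800 nM, the lower of the two numbers, and compound 1 lies higher at 33500 nM, a gap beyond the usual scatter. Compound 3 keeps the atoms of compound 2 but joins them differently, with isopropyl in place of propyl on a double-bonded chain carbon bound to a double-bonded chain carbon. Compound 1 also carries the 3-methylbut-1-en-1-yl group, but it differs from compound 2 elsewhere as well, so the two values do not isolate this change. No step beyond the scatter is therefore expected in this assay. The expected size of the change is a 1.1-fold higher number from compound 2 to compound 3 (0.04 log units; within the scatter). The estimated value for compound 3 is 13000 nM, with an expected range from 6000 nM to 28000 nM.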

Compound 3, half-maximal inhibitory concentration: 25300 nM
Estimate against measurement, compound 3: 1.9-fold (0.29 log units) below, within the range that was stated.
By their numbers in this assay, from the lowest: compound 2; then compounds 3 and 1 (each within the scatter of the next).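

In this assay, the change from propyl to isopropyl on a double-bonded chain carbon bound to a double-bonded chain carbon can now be read alone: it gives a 2.1-fold higher number from compound 2 to compound 3 (0.33 log units; beyond the scatter), a modest step between two compounds with the same atoms. With isopropyl held fixed, 3-methoxyphenyl in place of 1-methyl-1H-pyrazol-3-yl on a nitrogen on an aromatic ring gives a 1.3-fold lower number from compound 1 to compound 3 (0.12 log units; within the scatter), which separates the two changes that compounds 1 and 2 carried together. Nothing available accounts for the step at the chain.

The compounds shown leave open whether the propyl to isopropyl step would hold with 1-methyl-1H-pyrazol-3-yl on that nitrogen. They also leave open how a longer chain, or an amine carried on this chain, would read in this assay.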